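The source may hold more compounds than are shown below. What is called first, only, known or untested is meant among the compounds shown, and "the series" means these compounds.

Measured so far in a functional assay (mast cells) for inhibition, with Rattus norvegicus as the target (on this read-out lower numbers stand for an effect already at smaller amounts and higher numbers for an effect only at larger amounts of compound), on three compounds

Compound 1 (`COc1ccc(N/N=C2\CCC(C)n3c2ncc(C(=O)O)c3=O)cc1`), value 128000 nM
Compound 2 (`CC1CC/C(=N\Nc2ccc(C(F)(F)F)cc2)c2ncc(C(=O)O)c(=O)n21`), value 280 nM
Compound 3 (`CC1CC/C(=N\Nc2ccc(C(=O)O)cc2)c2ncc(C(=O)O)c(=O)n21`), value 1000000 nM

Compound 3 stands highest of the three, well clear of both others. Compound 4 (`CC1CC/C(=N\Nc2ccc(CC(=O)O)cc2)c2ncc(C(=O)O)c(=O)n21`) differs from it by one change (carboxymethyl in place of carboxy on an aromatic carbon), with carboxymethyl in place of carboxy on an aromatic carbon, para to a large group. Two measured steps at this same place bear on the change. One was large (a 3600-fold higher number from compound 2 to compound 3 (3.55 log units; beyond the scatter)) and the other modest (a 7.8-fold higher number from compound 1 to compound 3 (0.89 log units; beyond the scatter)), and both ended in the carboxy group of compound 3. Among the measured compounds shown here, no measured compound carries carboxymethyl, so the step remains uncertain. Carboxymethyl still holds a carboxy group, so a modest step to a lower number is expected in this assay, of about the size seen for compound 3 against compound 1 (a 7.8-fold higher number from compound 1 to compound 3 (0.89 log units; beyond the scatter)), and not a large one. The expected step (a 3.3-fold lower number from compound 3 to compound 4 (0.52 log units; beyond the scatter)) is modest. Compound 4 is estimated at 300000 nM within an expected range (50000 nM to 1500000 nM).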

Compound 4, half-maximal effective concentration: 3400 nM
The estimate for compound 4 lay 88-fold (1.95 log units) above the measured number, and the stated range ends above it.
By their numbers in this assay, from the lowest: compound 2; then compound 4; then compound 1; then compound 3.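

In (this assay), the position para to a large group responded not only to the presence of a carboxy group but also to how it is attached: carboxymethyl in place of carboxy gave (a 290-fold lower number from compound 3 to compound 4 (2.47 log units; beyond the scatter)). A carboxy group at the end of a chain therefore did not place the compound at the top of the series, since carboxymethyl also gave a lower number than methoxy (a 38-fold lower number from compound 1 to compound 4 (1.58 log units; beyond the scatter)). Trifluoromethyl still kept the lowest number, with carboxymethyl higher (a 12-fold higher number from compound 2 to compound 4 (1.08 log units; beyond the scatter)).

No measurement available here explains why this change has so large an effect. From the compounds shown here alone, it remains open whether a longer chain ending in a carboxylic acid would lower the number further, and where a methyl ester or a primary amide of the carboxymethyl group would fall.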